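Replacing the anilino group with pyrrolidin-1-yl

A few compounds are considered here, and "the series" means these few. Any claim that something is new, unique, unknown or untested is made for them only; others in the source may bear on it.

Among the measured compounds shown here, only two compounds have numbers so far. In a functional assay on MGC-803 cells (Homo sapiens) for inhibition, read by sulforhodamine B assay (on this read-out lower numbers stand for stronger inhibition and higher numbers for weaker inhibition), compound 1 (`O=C1C=C(Nc2ccc(Br)cc2)C(=O)c2c1nc1n2[C@H]2OC[C@@H](O)[C@H]2OC1`) gives 1010 nM, and compound 2 (`O=C1C=C(Nc2ccccc2)C(=O)c2c1nc1n2[C@H]2OC[C@@H](O)[C@H]2OC1`) gives 1730 nM. Compound 2 therefore cannot be told apart from compound 1, as the two numbers lie within the usual scatter of repeated measurements. For the measured compounds named here, the one measured step, a 1.7-fold higher number from compound 1 to compound 2 (0.23 log units; within the scatter), is hydrogen in place of bromo on an aromatic carbon.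

Compound 3 (`O=C1C=C(N2CCCC2)C(=O)c2c1nc1n2[C@H]2OC[C@@H](O)[C@H]2OC1`) keeps the shared core but carries pyrrolidin-1-yl in place of anilino on a double-bonded ring carbon. This removes the whole aromatic ring on which the measured step took place, so that step bears on the new change only loosely. Going by the values given here, no measured step replaces the anilino group itself, and the data offer no direction. The best anchor is compound 2 at 1730 nM, with a wide margin on either side. In this assay the expected step is a 1.2-fold lower number from compound 2 to compound 3 (0.06 log units; within the scatter), which is no step beyond the scatter. For compound 3 the estimated value is 1500 nM, with a range from 400 nM to 5500 nM.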

Compound 3, half-maximal inhibitory concentration: > 16000 nM
Compound 3: only a limit was reported; the forecaster's own chance of this, stated with the estimate: 8%; middle value at least 10-fold (1.02 log units) from the limit.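

The earlier step only exchanged bromo for hydrogen on the aromatic ring and stayed within the scatter, so it said little about how much this position matters. Replacing the whole group on the double-bonded ring carbon has a much clearer effect in this assay: pyrrolidin-1-yl in place of anilino gives an at least 9.2-fold higher number from compound 2 to compound 3 (0.96 log units; beyond the scatter), and pyrrolidin-1-yl in place of (4-bromophenyl)amino gives an at least 15-fold higher number from compound 1 to compound 3 (1.19 log units; beyond the scatter). The figure for compound 3 is a limit and not a measured number, so both steps give only a minimum size: the limit of > 16000 nM in this assay, at which 1 of the 3 values shown sits.

The compounds shown leave open which part of the change matters, as the aromatic ring and the hydrogen-bond donor on the nitrogen leave together, and the incoming ring is also smaller. A cyclopentylamino group, which holds a non-aromatic ring but keeps the hydrogen on the nitrogen, would separate these two features, and a methyl group on the anilino nitrogen would test the loss of that hydrogen while the aromatic ring stays in place.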